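From Compound 2 to Compound 4: Nitro Gives Way to Fluoro

The source may hold more compounds than are shown below. What is called first, only, known or untested is meant among the compounds shown, and "the series" means these compounds.

Of the compounds shown here, three sharing one core have been measured in a functional assay on HUVEC cells (Homo sapiens), read by fluorescence and microscopy, with a stated time of 6 h, tested at 10 uM; a lower number here means a stronger effect, a higher number a weaker effect of the compound at the concentration tested. Compound 1 `COc1cc2sc(Nc3ccccc3)c(C#N)c2cc1OC` gives 77%, compound 2 `N#Cc1c(Nc2ccc([N+](=O)[O-])cc2)sc2ccccc12` gives 8%, and compound 3 `N#Cc1c(Nc2cccc(O)c2)sc2ccccc12` gives 0%. Compound 2 thus stands second highest of the three numbers; compound 3 is its nearest neighbour, within the scatter, while compound 1 lies far above it, beyond the scatter. Compound 4 `N#Cc1c(Nc2ccc(F)cc2)sc2ccccc12` has not yet been measured; it differs from compound 2 by fluoro in place of nitro on an aromatic carbon. Going by the values given here, no step between measured compounds bears directly on this change. Because compound 2 gives 8%, the expected step is small and upward, a number 12 percentage points higher from compound 2 to compound 4 (beyond the scatter), likely within the scatter. Compound 4 is therefore estimated at 20%, in a range from 0% to 60%.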

Compound 4, a percentage reported as activity, at one concentration (the size of the read-out at that concentration, not a potency): 25%
For compound 4 the middle estimate is 5 percentage points below the measured one; the range from low to high includes it.
By their numbers in this assay, from the lowest: compounds 3 and 2 (each within the scatter of the next); then compound 4; then compound 1.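

In this assay, going by these compounds alone, the step of a number 17 percentage points higher from compound 2 to compound 4 (beyond the scatter) gives the first reading of a change in one place, and it shows that the group on this aromatic carbon, para to a large group, matters. Fluoro in place of nitro weakens the effect at the concentration tested, though only modestly. No measured evidence accounts for this step.

The compounds shown leave open whether the effect follows from losing nitro or from gaining fluoro. They also leave open how an amine or a carboxylic acid would read on this carbon.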